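From 6-fluoropyridin-3-yl to pyridin-3-yl in compound 3

This account rests on a few compounds, and the source may have more. Where it says the series, first, only, none or still open, it means among the compounds named here.

In a functional assay on MCF7 cells (Homo sapiens) for antiproliferative activity, read by sulforhodamine B assay, with a stated time of 48 h (a higher number here means a weaker inhibitor, a lower number a stronger inhibitor), compound 1 `COc1ccc(/C=C/C(=O)c2ccccc2-c2cccc(F)c2)cc1` gives 640 nM, while compound 2 `COc1ccc(/C=C/C(=O)c2ccccc2-c2ccc(F)nc2)cc1` gives 2700 nM, the higher of the two numbers. For the measured compounds named here, the only measured step, a 4.2-fold higher number from compound 1 to compound 2 (0.63 log units; beyond the scatter), puts 6-fluoropyridin-3-yl in place of 3-fluorophenyl. Compound 3 `COc1ccc(/C=C/C(=O)c2ccccc2-c2cccnc2)cc1` differs from compound 2 by hydrogen in place of fluoro on an aromatic carbon. Going by the values given here, the measured step changes the ring as well, so it bears only indirectly, and no measured step removes fluoro alone. The expected change is therefore none beyond the scatter, with a 1.2-fold lower number from compound 2 to compound 3 (0.09 log units; within the scatter) as the estimated step. Compound 3 is estimated at 2200 nM, within a range of 800 nM to 6000 nM.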

Compound 3, half-maximal inhibitory concentration: 830 nM
Compound 3: middle estimate off by 2.7-fold (0.42 log units), on the high side, within the range that was stated.
By their numbers in this assay, from the lowest: compounds 1 and 3 (each within the scatter of the next); then compound 2.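

In this assay, the step of a 3.3-fold lower number from compound 2 to compound 3 (0.51 log units; beyond the scatter) is hydrogen in place of fluoro alone, so the fluoro next to the ring nitrogen matters by itself. With that fluoro gone, the step of a 1.3-fold higher number from compound 1 to compound 3 (0.11 log units; within the scatter) stays within the scatter, so among these compounds the higher number goes with 6-fluoropyridin-3-yl and not with pyridin-3-yl. Nothing available explains this difference. As far as these compounds go, whether an amine or a methoxy group at this position would read like hydrogen or like fluoro stays open.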